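The source may hold more compounds than are shown below. What is called first, only, known or untested is meant among the compounds shown, and "the series" means these compounds.

In an ADME assay on Vero cells (Chlorocebus sabaeus) for cytotoxicity, read by MTT assay, with a stated time of 72 h (a higher number here means that more compound is tolerated, a lower number that less compound is tolerated), three compounds have been measured so far, and each of them came back only as a limit of the assay rather than as a number. Compound 1 `CC(C)Cc1ccc(C(=O)/C=C/c2ccc(C(=O)O)cc2)cc1` gives < 10 ug/mL, which is a limit, as the line the limit of < 10 ug/mL in this assay, at which 1 of the 3 values shown sits, records. Compound 3 `COC(=O)c1cc(-c2cccc(NC(=O)c3ccc(OCc4ccc(Cl)cc4)cc3)c2)on1` gives > 80 ug/mL, also a limit, shown by the limit of > 80 ug/mL in this assay, at which 1 of the 3 values shown sits. Compound 2 `COC(=O)c1cc(-c2cccc(NC(=O)c3ccc(/C=C/C(=O)c4cccc([N+](=O)[O-])c4)cc3)c2)on1` gives > 40 ug/mL, a limit too, as the limit of > 40 ug/mL in this assay, at which 1 of the 3 values shown sits, states; so compound 2 is known only to be tolerated up to that point, and no number places it against the others.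

Compound 4 `COC(=O)c1cc(-c2cccc(NC(=O)c3ccc(/C=C/C(=O)c4ccc(OC)cc4OC)cc3)c2)on1` has not yet been measured in this assay. It differs from compound 2 in one place: 2,4-dimethoxyphenyl in place of 3-nitrophenyl on a carbonyl carbon. Among the measured compounds shown here, no pair of measured compounds differing in one place is available, so there is no measured step to lean on; the only anchor is the limit of compound 2.

Given that, the step from compound 2 to compound 4 is expected to be small, a step that the limit leaves unreadable from compound 2 to compound 4, with no change beyond the usual scatter anticipated in either direction. Compound 4 is therefore expected to give about 50 ug/mL in this assay, with a likely range from 25 ug/mL to 100 ug/mL, and a good chance that the result is again reported only as a limit.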

Compound 4, half-maximal cytotoxic concentration: > 50 ug/mL
Compound 4 ended at the assay's limit; the forecaster's own chance of this, stated with the estimate: 60%; the middle value lies on the limit itself.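

Among the compounds shown here, compound 2 and compound 4 both stand only as limits in this assay, and no step between them can be read. The compounds shown leave open where the true half-maximal cytotoxic concentration of either compound lies, and whether 2,4-dimethoxyphenyl in place of 3-nitrophenyl on a carbonyl carbon changes it at all.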